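Alpha-substituent on the amide chain: aryl versus benzyl

The source may report more compounds than this note shows. Statements on the series, on what has been measured and on what is new or still open speak of the compounds shown alone.

Measured so far:
- compound 1 `CC1CCN(c2nc(C(F)(F)F)ccc2CNC(=O)C(c2ccc(NS(C)(=O)=O)c(F)c2)C2CCCC2)CC1`: 88.7 nM
- compound 2 `Cc1ccc(C(C(=O)NCc2ccc(C(F)(F)F)nc2N2CCC(C)CC2)c2ccc(NS(C)(=O)=O)c(F)c2)cc1`: 1.1 nM

In an assay on CHO cells for antagonist activity at transient receptor potential cation channel subfamily V member 1 (Homo sapiens), read by FLIPR (on this read-out higher numbers stand for weaker inhibition and lower numbers for stronger inhibition), compound 2 gives 1.1 nM, the lowest of the two numbers; in the same assay compound 1 gives 88.7 nM. Within the data shown here, the one measured step, an 81-fold lower number from compound 1 to compound 2 (1.91 log units; beyond the scatter), is large and beyond the scatter, so the aromatic ring directly on the saturated chain carbon is tied to the strong result of compound 2.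

Compound 3 `CC1CCN(c2nc(C(F)(F)F)ccc2CNC(=O)C(Cc2ccccc2)c2ccc(NS(C)(=O)=O)c(F)c2)CC1` is not yet measured. It differs from compound 2 by benzyl in place of 4-methylphenyl on a saturated chain carbon bound to an aromatic carbon and a carbonyl carbon. The ring therefore stays, but now sits one saturated carbon further from the chain carbon that carries the aromatic carbon and the carbonyl carbon, and the methyl on the ring is gone. Among the measured compounds shown here, no measured step covers this rearrangement; the step from compound 1 to compound 2 only shows that the direct aryl attachment matters a great deal. Without that direct attachment, some loss against compound 2 is expected, though less than the full gap back to compound 1.

The estimate for compound 3 in this assay is 12 nM, range 2.5 nM to 60 nM, an expected step of an 11-fold higher number from compound 2 to compound 3 (1.04 log units; beyond the scatter).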

Compound 3, inhibition constant: 65.9 nM
Compound 3: middle estimate off by 5.5-fold (0.74 log units), on the low side, outside the stated range (above it).
By their numbers in this assay, from the lowest: compound 2; then compounds 3 and 1 (each within the scatter of the next).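

In this assay, a 60-fold higher number from compound 2 to compound 3 (1.78 log units; beyond the scatter), although the two groups have the same heavy-atom count and each carries one six-membered aromatic ring, so at this position the same atoms joined differently give a large difference in the read-out. Benzyl also offers no clear gain over the non-aromatic group, with a 1.3-fold lower number from compound 1 to compound 3 (0.13 log units; within the scatter); among the three compounds, the low number therefore belongs to 4-methylphenyl alone, and the presence of an aromatic ring in the group is not enough to give it. No measurement available here explains this difference.

The change from 4-methylphenyl to benzyl both removes the methyl from the ring and places a saturated carbon in front of the ring, and the compounds shown do not separate these two changes. Unsubstituted phenyl and 4-methylbenzyl at this place would each address one of them, while 2-phenylethyl would show how the read-out responds to a longer chain before the ring.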